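Adding a sec-butyl side chain to a glycine-type amide

A few compounds are considered here, and "the series" means these few. Any claim that something is new, unique, unknown or untested is made for them only; others in the source may bear on it.

Measured so far:
- compound 1, `CCC(C)C(C(=O)Nc1ccc(C(C)=O)cc1)N(C(=O)c1ccccc1)S(=O)(=O)c1ccc(C)cc1`: 47.3%
- compound 2, `CC(=O)c1ccc(NC(=O)CN(C(=O)c2ccccc2)S(=O)(=O)c2ccccc2)cc1`: 45.4%

In a functional assay for inhibition, read by spectrophotometry, with a stated time of 20 min, tested at 5 mg/mL (on this read-out lower numbers stand for a weaker effect and higher numbers for a stronger effect at the one concentration tested), compound 1 gives 47.3% and compound 2 gives 45.4%. Compound 2 has the lowest of the two numbers, but its nearest neighbour, compound 1, sits only a small distance higher, a gap within the usual scatter, so the two cannot be told apart on this read-out.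

Compound 3, `CCC(C)C(C(=O)Nc1ccc(C(C)=O)cc1)N(C(=O)c1ccccc1)S(=O)(=O)c1ccccc1`, has not been measured. It differs from compound 2 in one place: sec-butyl in place of hydrogen on a saturated chain carbon bound to an amide-type nitrogen and a carbonyl carbon. Among the measured compounds shown here, no pair of measured compounds shows this exact change, so the size of its effect is not known from the numbers in hand. With the two measured values lying together and nothing pointing either way, no step beyond the scatter is expected, and compound 3 is estimated at 46%, within 34% to 58%. The change from compound 2 to compound 3 is thus expected to be a number 0.6 percentage points higher from compound 2 to compound 3 (within the scatter).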

Compound 3, a percentage reported as inhibition, at one concentration (the size of the read-out at that concentration, not a potency): 16.8%
The estimate for compound 3 lay 29.2 percentage points above the measured number; measured number outside the range, below it.
By their numbers in this assay, from the lowest: compound 3; then compounds 2 and 1 (each within the scatter of the next).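

In this assay the saturated chain carbon bound to an amide-type nitrogen and a carbonyl carbon proves sensitive to what it carries: sec-butyl in place of hydrogen gives a number 28.6 percentage points lower from compound 2 to compound 3 (beyond the scatter) at the one concentration tested. The aromatic carbon matters just as clearly once sec-butyl is present, since hydrogen in place of methyl gives a number 30.5 percentage points lower from compound 1 to compound 3 (beyond the scatter) and the two changes therefore cannot be judged independently of each other. No measurement at hand explains either step.

As far as these compounds go, it remains open whether the drop at the chain carbon is specific to sec-butyl or would also appear with isopropyl, benzyl or a longer chain. Also unresolved is what methyl on the aromatic carbon does without sec-butyl, and whether ethyl or chlorine there would serve as methyl does.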